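Replacing the phenyl of compound 2 with iodo

This account rests on a few compounds, and the source may have more. Where it says the series, first, only, none or still open, it means among the compounds named here.

In a functional assay on HepG2 cells (Homo sapiens) for antiproliferative activity, read by XTT assay, with a stated time of 72 h (on this read-out higher numbers stand for weaker inhibition and lower numbers for stronger inhibition), compound 1 `COc1ncnc2c1c(-c1ccoc1)cn2[C@@H]1O[C@H](CO)[C@@H](O)[C@H]1O` gives 290 nM. Going by these compounds, compound 2 `COc1ncnc2c1c(-c1ccccc1)cn2[C@@H]1O[C@H](CO)[C@@H](O)[C@H]1O` returns only a limit of the assay, > 20000 nM, so it sits at the limit of > 20000 nM in this assay, at which 1 of the 2 values shown sits, and its exact potency is unknown. Going by the values given here, the one measured step, an at least 68-fold higher number from compound 1 to compound 2 (1.83 log units; beyond the scatter), is therefore a change from a real number to a limit. Compound 3 `COc1ncnc2c1c(I)cn2[C@@H]1O[C@H](CO)[C@@H](O)[C@H]1O` differs from compound 2 by iodo in place of phenyl on an aromatic carbon. Among the compounds with values here, no measured step covers an exchange of phenyl for iodo, so the single large step from compound 1 to compound 2 bears on it only indirectly: it shows that the group on this aromatic carbon can shift the read-out by a large amount, and that a small iodo need not sit where the phenyl does. The expected step is an at least 6.6-fold lower number from compound 2 to compound 3 (0.82 log units; beyond the scatter), toward a stronger number. Compound 3 is estimated at 3000 nM, within 300 nM to 20000 nM.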

Compound 3, half-maximal inhibitory concentration: > 20000 nM
Compound 3 was reported as a limit; the forecaster's own chance of this, stated with the estimate: 25%; at least 6.6-fold (0.82 log units) between middle value and limit.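

Compound 3 is also reported only as a limit of the assay: the limit of > 20000 nM in this assay, at which 2 of the 3 values shown sit.

Iodo in place of furan-3-yl gives an at least 68-fold higher number from compound 1 to compound 3 (1.83 log units; beyond the scatter), so a single iodine atom on this aromatic carbon, like the phenyl ring of compound 2, leaves the read-out without a measured number. Of the three groups shown at this position, furan-3-yl is therefore the only one with a real value, and neither the large phenyl nor the small iodo restores one. With a limit on both sides, the step between compound 2 and compound 3 cannot be read, so phenyl and iodo cannot be ranked against each other.

The compounds shown leave open which feature of furan-3-yl goes with the measured value. They also leave open whether a furan-2-yl, a thiophen-3-yl or an amine on this carbon would give a real number.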